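Notes on the silicon substituent series

This account rests on a few compounds, and the source may have more. Where it says the series, first, only, none or still open, it means among the compounds named here.

Compound 2 `CCN(C/C=C/C#CC(C)(C)C)Cc1cccc(OC[Si](C)(C)c2ccccc2-c2ccsc2)c1` holds the highest number of the two measured in a functional assay on liver (Sus scrofa) for inhibition of squalene monooxygenase (Homo sapiens), using microsomes (on this read-out higher numbers stand for weaker inhibition and lower numbers for stronger inhibition), giving 10000 nM; the nearest, compound 1 `CCN(C/C=C/C#CC(C)(C)C)Cc1cccc(OC[Si](C)(C)c2cccc(C)c2)c1`, gives 3000 nM, and the step of a 3.3-fold higher number from compound 1 to compound 2 (0.52 log units; beyond the scatter) lies beyond the scatter. Compound 3 `CCN(C/C=C/C#CC(C)(C)C)Cc1cccc(OC[Si](C)(C)Cc2ccccc2)c1` differs from compound 2 by benzyl in place of 2-(thiophen-3-yl)phenyl on a silicon. Among the measured compounds shown here, only that single step bears on it: the entry of 2-(thiophen-3-yl)phenyl raised the number, so its departure for benzyl is expected to lower it by a comparable amount, back toward compound 1. For compound 3 the expected value is 4000 nM (range 1500 nM to 12000 nM), the estimated step being a 2.5-fold lower number from compound 2 to compound 3 (0.40 log units; beyond the scatter).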

Compound 3, half-maximal inhibitory concentration: 130 nM
Beside the measured number, compound 3's estimate is 31-fold (1.49 log units) above it, and the stated range ends above it.
By their numbers in this assay, from the lowest: compound 3; then compound 1; then compound 2.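

In this assay benzyl in place of 2-(thiophen-3-yl)phenyl on the silicon gives a 77-fold lower number from compound 2 to compound 3 (1.89 log units; beyond the scatter) and benzyl in place of 3-methylphenyl gives a 23-fold lower number from compound 1 to compound 3 (1.36 log units; beyond the scatter) as well, so the lower number does not rest on a single partner. Changes to this silicon substituent can therefore move the number much further than the earlier pair showed. Nothing at hand accounts for the drop. Still open, from the compounds shown here alone, is whether a longer chain such as 2-phenylethyl on the silicon, or a fluorine on the benzyl ring, keeps the number this low.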